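Swapping Sulfur and Methylene on the Shared Core

A few compounds are considered here, and "the series" means these few. Any claim that something is new, unique, unknown or untested is made for them only; others in the source may bear on it.

Measured compounds and their values:
compound 1 `CCCCCNc1ncnc2c1ncn2[C@@H]1O[C@H](CO)[C@@H](O)[C@H]1O` in an assay on isolated protein for binding affinity to Equilibrative nucleoside transporter 1 (Homo sapiens) (on this read-out lower numbers stand for stronger inhibition and higher numbers for weaker inhibition), gives 13500 nM
compound 2 `OC[C@H]1O[C@@H](n2cnc3c(SC4CCCCC4)ncnc32)[C@H](O)[C@@H]1O` in this assay gives 6310 nM
compound 3 `Cc1cccc(CSc2ncnc3c2ncn3[C@@H]2O[C@H](CO)[C@@H](O)[C@H]2O)c1` in this assay gives 12000 nM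

Compound 3 holds the second highest of the three numbers. Its nearest neighbour is compound 1, a gap within the scatter, and the step of a 1.9-fold higher number from compound 2 to compound 3 (0.28 log units; within the scatter) is also within the scatter. The step of a 1.1-fold lower number from compound 1 to compound 3 (0.05 log units; within the scatter) shows much the same picture.

Compound 4 `OC[C@H]1O[C@@H](n2cnc3c(CSc4ccccc4Cl)ncnc32)[C@H](O)[C@@H]1O` differs from compound 3 in one place: ((2-chlorophenyl)sulfanyl)methyl in place of (3-methylbenzyl)sulfanyl on an aromatic carbon. Sulfur and the methylene trade places along the link to the ring, and a chlorine sits where the methyl stood. Within the data shown here, none of the measured steps cover this exact exchange; the closest is the step from compound 2 to compound 3, which replaced a cyclohexyl with a benzyl on sulfur and stayed within the scatter. The three measured numbers lie in a narrow band, so a step for compound 4 of roughly a 1.2-fold lower number from compound 3 to compound 4 (0.08 log units; within the scatter) is expected, not beyond the scatter. Compound 4 is estimated at 10000 nM, within 4000 nM to 25000 nM.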

Compound 4, half-maximal inhibitory concentration: 1780 nM
Compound 4: the middle estimate sits 5.6-fold (0.75 log units) above what was measured; measured number outside the range, below it.
By their numbers in this assay, from the lowest: compound 4; then compounds 2, 3 and 1 (each within the scatter of the next, the first and the last beyond it).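

Among the first three compounds, changing the group on this aromatic carbon moved the number only a little, whereas ((2-chlorophenyl)sulfanyl)methyl brings a 6.7-fold lower number from compound 3 to compound 4 (0.83 log units; beyond the scatter) and a 3.5-fold lower number from compound 2 to compound 4 (0.55 log units; beyond the scatter) and also a 7.6-fold lower number from compound 1 to compound 4 (0.88 log units; beyond the scatter) in this assay and makes compound 4 the strongest inhibitor of the four. This position can therefore respond clearly to the group it carries, even though both groups in the step from compound 3 hold the same count of heavy atoms and one carbon-only aromatic ring. What lies behind this gain remains unexplained, with no supporting measurement available here.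

Sulfur and methylene trade places and chlorine replaces methyl in one step, so the share of each change stays unknown. Also open, going by these compounds, is how a carboxylic acid, an amine or a longer chain on this carbon would fare.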